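Compound 4: an open-chain group replaces the aromatic ring

The source may report more compounds than this note shows. Statements on the series, on what has been measured and on what is new or still open speak of the compounds shown alone.

In a functional assay on MCF7 cells (Homo sapiens) for inhibition, read by MTT assay, with a stated time of 48 h (a lower number here means a stronger inhibitor, a higher number a weaker inhibitor), compound 3 `CCOC(=O)C1=C(N/C=N/c2ccc(C)cc2)Nc2[nH]nc(C)c2C1c1ccc(N(C)C)cc1` gives 50500 nM and compound 2 `CCOC(=O)C1=C(N/N=C(/Br)c2ccccc2)Nc2[nH]nc(C)c2C1c1ccc(N(C)C)cc1` gives 78400 nM within the scatter of it, while compound 1 `CCOC(=O)C1=C(N/C=N/c2cccnc2Cl)Nc2[nH]nc(C)c2C1c1ccc(N(C)C)cc1` is the strongest of the three at 4180 nM in these notes. The change to compound 4 `CCOC(=O)C1=C(N/N=C(/Cl)C#N)Nc2[nH]nc(C)c2C1c1ccc(N(C)C)cc1` is as follows (a group of 5 heavy atoms (2 carbon, 2 nitrogen, 1 chlorine; no ring) in place of a group of 9 heavy atoms (8 carbon, 1 nitrogen; one six-membered aromatic ring of carbon only), on an amine nitrogen). Among the measured compounds shown here, no measured step removes the aromatic ring, so the guidance is indirect. Compound 4 lacks the 2-chloropyridin-3-yl group that only compound 1 carries. Both large steps leave that group (a 19-fold higher number from compound 1 to compound 2 (1.27 log units; beyond the scatter) and a 12-fold higher number from compound 1 to compound 3 (1.08 log units; beyond the scatter)), and the remaining step stays within the scatter (a 1.6-fold lower number from compound 2 to compound 3 (0.19 log units; within the scatter)). No step beyond the scatter is therefore expected in this assay (a 1.4-fold lower number from compound 3 to compound 4 (0.16 log units; within the scatter)). Compound 4 is estimated at 35000 nM with 8000 nM to 120000 nM as the expected range.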

Compound 4, half-maximal inhibitory concentration: 23200 nM
Beside the measured number, compound 4's estimate is 1.5-fold (0.18 log units) above it; the measured number falls inside the stated range.
By their numbers in this assay, from the lowest: compound 1; then compound 4; then compounds 3 and 2 (each within the scatter of the next).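

On the amine nitrogen, the six-membered aromatic ring is not needed to hold activity in this assay: the open-chain group gives a 2.2-fold lower number from compound 3 to compound 4 (0.34 log units; beyond the scatter) and a 3.4-fold lower number from compound 2 to compound 4 (0.53 log units; beyond the scatter). The 2-chloropyridin-3-yl group still keeps the lower number, with a 5.6-fold higher number from compound 1 to compound 4 (0.74 log units; beyond the scatter). No supporting data explain these steps.

On these data alone, it remains open whether the lower number of compound 4 would persist with a plain ethyl chain or a carboxylic acid on this nitrogen. As far as these compounds go, whether the 2-chloropyridin-3-yl group would keep its lead over those groups is also open.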